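The source may hold more compounds than are shown below. What is called first, only, known or untested is meant among the compounds shown, and "the series" means these compounds.

Compound 1 `Cc1ccc2c(O)c(C(=O)NC3CCC(C)CC3)cnc2n1` and compound 2 `Cc1ccc2c(O)c(C(=O)NCCC(C)C)cnc2n1` share one core and differ only in the group carried on the amide-type nitrogen. In an assay for binding affinity to adenosine receptor A1 (Bos taurus) (a lower number here means a stronger inhibitor, a higher number a weaker inhibitor), compound 1 gives 6000 nM. Compound 2 reaches only a limit of this assay, > 10000 nM, so no number is known for it; this sits at the limit of > 10000 nM in this assay, at which 1 of the 2 values shown sits. The step of an at least 1.6-fold higher number from compound 1 to compound 2 (0.22 log units; that floor lies within the scatter) is therefore a floor rather than a measured distance, and compound 2 stands at the weak end of the two results, without a firm position of its own.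

Compound 3 `COc1ccc(CNC(=O)c2cnc3nc(C)ccc3c2O)cc1` introduces the change (4-methoxyphenyl in place of isobutyl on a saturated chain carbon bound to an amide-type nitrogen). Among the measured compounds shown here, the only measured step that touches this part of the molecule is an at least 1.6-fold higher number from compound 1 to compound 2 (0.22 log units; that floor lies within the scatter), which stays within the scatter, so swapping one group for another on this side of the amide has so far produced no movement that can be trusted. With nothing pointing in either direction, the expected step of a number no higher from compound 2 to compound 3 (the limit leaves the size open) in this assay is none beyond the scatter. For compound 3 the estimated value is 10000 nM, expected to lie between 2500 nM and 40000 nM.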

Compound 3, inhibition constant: > 10000 nM
Compound 3 was reported as a limit; the forecaster's own chance of this, stated with the estimate: 55%; the middle value lies on the limit itself.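

Compound 3 reaches only a limit of this assay at > 10000 nM and has no number of its own. Among the compounds shown here, compound 2 also stands at a limit, so no step from compound 2 to compound 3 can be read: the limit of > 10000 nM in this assay, at which 2 of the 3 values shown sit. The compounds shown leave open where compound 2 and compound 3 really lie, and whether isobutyl or 4-methoxyphenyl gives the stronger binding.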